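Methyl on the amide nitrogen of compound 2

The source may hold more compounds than are shown below. What is called first, only, known or untested is meant among the compounds shown, and "the series" means these compounds.

Of the compounds shown here, two on the shared core have been measured so far. In a functional assay on cells (B cell, Homo sapiens) for inhibition, read by thymidine incorporation, with stated times of 30 min and 72 h (on this read-out higher numbers stand for weaker inhibition and lower numbers for stronger inhibition), compound 1 `C[C@H](Nc1ncnc(N)c1C#N)c1nc2ccc(F)cc2c(-c2ccccn2)c1-c1ccccn1` gives 4.6 nM. Compound 2 `C[C@H](Nc1ncnc(N)c1C#N)c1nc2ccc(F)cc2c(C(N)=O)c1-c1ccccc1` gives 1.8 nM in this assay, the lower of the two numbers, and its gap to compound 1 lies beyond the scatter.

Compound 3 `CNC(=O)c1c(-c2ccccc2)c([C@H](C)Nc2ncnc(N)c2C#N)nc2ccc(F)cc12` is still unmeasured and departs from compound 2 in one place: methyl in place of hydrogen on an amide-type nitrogen. This is methyl in place of hydrogen on an amide-type nitrogen, or carbamoyl to methylcarbamoyl. Among the measured compounds shown here, compounds 1 and 2 differ in more than one place, so no measured step shows the size of this change directly, and the expectation rests on the structural change and on the value of compound 2 alone.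

A small move toward a higher number in this assay is expected, meaning somewhat weaker inhibition, and it may not clear the scatter. The expected size is a 1.9-fold higher number from compound 2 to compound 3 (0.29 log units; within the scatter). The estimate for compound 3 is 3.5 nM, with an expected range from 1.2 nM to 10 nM.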

Compound 3, half-maximal inhibitory concentration: 1.9 nM
Estimate against measurement, compound 3: 1.8-fold (0.27 log units) above; measured number inside the range.
By their numbers in this assay, from the lowest: compounds 2 and 3 (each within the scatter of the next); then compound 1.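

In this assay, methyl in place of hydrogen on the amide-type nitrogen gives a 1.1-fold higher number from compound 2 to compound 3 (0.02 log units; within the scatter) and so leaves carbamoyl and methylcarbamoyl indistinguishable on this read-out. Among the compounds shown here, this is the first step that changes one place only, and it shows that the amide hydrogen can be replaced by methyl at this nitrogen without a difference beyond the scatter, which compounds 1 and 2, differing in more than one place, could not show. No accompanying measurement offers an explanation for this result.

As far as these compounds go, whether this holds beyond a single added carbon remains open, since an ethyl group or a longer chain on this nitrogen, a dimethylamide with both amide hydrogens replaced, or a carboxylic acid in place of the carbamoyl could each give a different number. A single step from a single parent also leaves open whether the same methyl change would give a similar result elsewhere on the shared core or in the presence of other groups.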